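The compounds below may be only part of what the source reports. "The series", "measured", "known", "first", "only" and "open" are said of these compounds alone.

In a functional assay on 786-0 cells (Homo sapiens) (on this read-out lower numbers stand for stronger inhibition of growth and higher numbers for weaker inhibition of growth), compound 1 `Cc1cc(C)c2c(O)cc(-c3ccc(Cl)cc3)nc2n1` gives 21400 nM while compound 2 `COc1ccc(-c2cc(O)c3cccnc3n2)cc1` gives 56200 nM and compound 3 `COc1ccc(-c2cc(O)c3c(C)cc(C)nc3n2)cc1` gives 58900 nM on the same read-out. Compound 3 thus sits within the usual scatter of compound 2, and both show weaker inhibition of growth than compound 1. Compound 4 `COc1ccc(-c2cc(O)c3ccc(C)nc3n2)cc1` differs from compound 3 by hydrogen in place of methyl on an aromatic carbon. Going by the values given here, the one measured step (a 2.8-fold higher number from compound 1 to compound 3 (0.44 log units; beyond the scatter)) was modest but changed another place, so it offers little guidance. More useful is that both methyl groups of compound 3 are absent from compound 2, which gives 56200 nM in the same range. In this assay the expected step (a 1.0-fold lower number from compound 3 to compound 4 (0.01 log units; within the scatter)) therefore stays within the scatter. The estimate for compound 4 is 57000 nM with an expected range from 30000 nM to 100000 nM on this read-out.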

Compound 4, concentration for 50% growth inhibition: > 100000 nM
Compound 4 gave a limit, no number (the forecaster's own chance of this, stated with the estimate: 10%); middle value at least 1.7-fold (0.24 log units) away from the limit.
By their numbers in this assay, from the lowest: compound 1; then compounds 2 and 3 (each within the scatter of the next). At a limit, above all of these: compound 4.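

Compound 4 gives > 100000 nM in this assay, which is a limit of the assay and not a number. Hydrogen in place of the methyl opposite the ring nitrogen gives an at least 1.6-fold higher number from compound 3 to compound 4 (0.22 log units; that floor lies within the scatter), while adding the other methyl to the core gives an at least 1.7-fold higher number from compound 2 to compound 4 (0.25 log units; that floor lies within the scatter). Both floors lie within the scatter, so neither change is shown to weaken growth inhibition, yet neither can be called silent, and their true sizes stay unknown because the result is a limit: the limit of > 100000 nM in this assay, at which 1 of the 4 values shown sits.

Going by these compounds, whether this carbon tolerates anything other than methyl or hydrogen remains open. An ethyl group or an amine there could show how much this position matters.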